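Compound 4: A Dihydroxyphenyl in Place of Fluorophenyl

The source may report more compounds than this note shows. Statements on the series, on what has been measured and on what is new or still open speak of the compounds shown alone.

Three compounds have been measured in a functional assay on the whole organism (strain Wistar) for inhibition, with Rattus norvegicus as the target, read by paw edema, with a stated time of 4 h, at a dose of 10 mg/kg by the intraperitoneal route; on this read-out higher numbers stand for more inhibition at the one dose given (going by the name of the read-out) and lower numbers for less inhibition:
compound 1 `O=C(N/N=C/c1ccccc1)c1cccnc1Nc1cccc(C(F)(F)F)c1`, 31%;
compound 2 `O=C(N/N=C/c1ccc(F)cc1)c1cccnc1Nc1cccc(C(F)(F)F)c1`, 36.5%;
compound 3 `O=C(N/N=C/c1cccc(Cl)c1)c1cccnc1Nc1cccc(C(F)(F)F)c1`, 40.4%.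

Compound 2 stands second highest of the three numbers. Its nearest neighbour is compound 3, a number 3.9 percentage points higher from compound 2 to compound 3 (within the scatter), and its furthest is compound 1, a number 5.5 percentage points higher from compound 1 to compound 2 (within the scatter). Compound 4 `O=C(N/N=C/c1ccc(O)c(O)c1)c1cccnc1Nc1cccc(C(F)(F)F)c1` has not been measured. It differs from compound 2 in one place: 3,4-dihydroxyphenyl in place of 4-fluorophenyl on a carbon with a double bond to nitrogen.

For the measured compounds named here, no measured step exchanges a fluorine for a hydroxyl or introduces a second hydroxyl, so the only guide is the set of changes already made on the same ring: a number 5.5 percentage points higher from compound 1 to compound 2 (within the scatter), a number 9.4 percentage points higher from compound 1 to compound 3 (within the scatter) and a number 3.9 percentage points higher from compound 2 to compound 3 (within the scatter), every one of them within the scatter. Those steps suggest that substitution on this ring moves the read-out little. Compound 4 is therefore expected to show a number 0.5 percentage points higher from compound 2 to compound 4 (within the scatter) in this assay, nothing beyond the scatter, with the caveat that a dihydroxyphenyl has no precedent among these three. For compound 4 the estimate in this assay is 37%, expected to fall between 22% and 52%.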

Compound 4, a percentage reported as inhibition, in the whole organism at one dose (the size of the read-out at that dose, not a potency): 21.1%
Compound 4: the middle estimate sits 15.9 percentage points above what was measured; measured number outside the range, below it.
By their numbers in this assay, from the lowest: compounds 4, 1, 2 and 3 (each within the scatter of the next, the first and the last beyond it).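

In this assay the ring on the carbon with a double bond to nitrogen proves able to move the read-out beyond the scatter, which neither the fluoro nor the chloro change did: 3,4-dihydroxyphenyl gives a number 15.4 percentage points lower from compound 2 to compound 4 (beyond the scatter) and a number 19.3 percentage points lower from compound 3 to compound 4 (beyond the scatter). The unsubstituted ring gives a smaller gap, with a number 9.9 percentage points lower from compound 1 to compound 4 (within the scatter), so among these compounds the 3,4-dihydroxyphenyl separates clearly only from the two that carry a halogen. Nothing available explains this response to the change.

The compounds shown leave open whether a single hydroxyl on this ring would match the pair. They also leave open whether a methoxy, an amine or a carboxylic acid there would read like compound 4 or like compound 2 and compound 3.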